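Notes on compounds 2 and 3, hydroxymethyl for methoxycarbonyl

The compounds below may be only part of what the source reports. "The series", "measured", "known", "first", "only" and "open" are said of these compounds alone.

Among the measured compounds shown here, compound 2 `COC(=O)CNc1c(C(=O)NCc2ccc(F)cc2)nc(Br)c2cccnc12` gives 10000 nM in a functional assay on MDA-MB-435 cells (Homo sapiens) for cytotoxicity, read by MTT assay, with a stated time of 72 h (on this read-out lower numbers stand for stronger inhibition and higher numbers for weaker inhibition), and stands as the only plain number in this set. Compound 1 `N[C@H]1CC[C@H](Nc2c(C(=O)NCc3ccco3)nc(Br)c3cccnc23)CC1` reaches only a limit in this assay, namely > 10000 nM, which is the limit of > 10000 nM in this assay, at which 1 of the 2 values shown sits. Compound 3 `O=C(NCc1ccc(F)cc1)c1nc(Br)c2cccnc2c1NCCO` differs from compound 2 by hydroxymethyl in place of methoxycarbonyl on a saturated chain carbon bound to a nitrogen on an aromatic ring. For the measured compounds named here, no measured step of a single change exists here, so its size cannot be read from a neighbour. The step of no change at the digits printed from compound 2 to compound 3 (within the scatter) is expected to stay within the scatter, with compound 2 at 10000 nM as the only measured starting point. Compound 3 is expected to give 10000 nM, with a range from 4000 nM to 25000 nM.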

Compound 3, half-maximal inhibitory concentration: > 20000 nM
Compound 3 ended at the assay's limit; the forecaster's own chance of this, stated with the estimate: 50%; at least 2.0-fold (0.30 log units) between middle value and limit.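

In this assay compound 3 reaches only a limit, not a number: the limit of > 20000 nM in this assay, at which 1 of the 3 values shown sits. Hydroxymethyl in place of methoxycarbonyl on this saturated chain carbon gives an at least 2.0-fold higher number from compound 2 to compound 3 (0.30 log units; that floor lies within the scatter), the first step read at this position. The change brings no stronger number here, and its real size stays unread.

The compounds shown leave open whether an amine or a carboxylic acid in place of hydroxymethyl, or a longer chain, would give a lower number in this assay.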